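The source may hold more compounds than are shown below. What is called first, only, known or untested is meant among the compounds shown, and "the series" means these compounds.

In a toxicity assay on THP-1 cells (Homo sapiens) for inhibition (a lower number here means that less compound is tolerated, a higher number that more compound is tolerated), compound 1 `Cn1c(-c2ccccc2)cnc1NC(=O)c1cccc(Cl)c1` gives > 50000 nM, which is a limit of the assay and not a number. Compound 2 `Cn1c(-c2cccc(C#N)c2)cnc1NC(=O)c1ncc[nH]1` gives > 50000 nM, also a limit and not a number. The evidence so far is therefore (the limit of > 50000 nM in this assay, at which 2 of the 2 values shown sit). Compound 3 `Cn1c(-c2ccccc2)cnc1NC(=O)c1ncc[nH]1` differs from compound 2 by a single change, hydrogen in place of cyano on an aromatic carbon. Within the data shown here, no measured pair shows the effect of this change, so no step beyond the usual scatter is expected in this assay. The expected value for compound 3 is 50000 nM, with an estimated range from 25000 nM to 100000 nM.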

Compound 3, half-maximal cytotoxic concentration: > 100000 nM
Compound 3: no number, only a limit; the forecaster's own chance of this, stated with the estimate: 85%; at least 2.0-fold (0.30 log units) between middle value and limit.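

Compound 1, compound 2 and compound 3 all give limits and not numbers, so the steps from compound 1 and compound 2 to compound 3 cannot be read. The compounds shown leave open what actual values they would give in this assay, and whether either change has any effect.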